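This account rests on a few compounds, and the source may have more. Where it says the series, first, only, none or still open, it means among the compounds named here.

Working notes on the series, all read in a functional assay on K562 cells (Homo sapiens), read by MTT assay, with a stated time of 72 h; on this read-out lower numbers stand for stronger inhibition and higher numbers for weaker inhibition. Compound 1 (`CN(C)c1ncnc2c1c(-c1ccoc1)cn2[C@@H]1O[C@H](CO)[C@@H](O)[C@H]1O`) gives 1540 nM, and compound 2 (`CN(C)c1ncnc2c1c(-c1ccsc1)cn2[C@@H]1O[C@H](CO)[C@@H](O)[C@H]1O`) gives 530 nM. Compound 3 (`Cc1ncnc2c1c(-c1ccoc1)cn2[C@@H]1O[C@H](CO)[C@@H](O)[C@H]1O`) stands at > 20000 nM, which is a limit of the assay and not a number. Of the three measured compounds, only this one has no numerical value.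

Compound 4 (`Cc1ncnc2c1c(-c1ccsc1)cn2[C@@H]1O[C@H](CO)[C@@H](O)[C@H]1O`) carries thiophen-3-yl in place of furan-3-yl on an aromatic carbon. The same exchange has been measured once, a 2.9-fold lower number from compound 1 to compound 2 (0.46 log units; beyond the scatter), a modest step beyond the scatter, and this is the direct precedent. The other measured step, an at least 12-fold higher number from compound 1 to compound 3 (1.11 log units; beyond the scatter), is large and places the methyl compounds on different ground, so the transfer rests on a single pair and remains uncertain.

A modest step towards a lower number is therefore expected in this assay, and a result at the limit remains possible. The estimated step is an at least 2.5-fold lower number from compound 3 to compound 4 (0.39 log units; beyond the scatter). The estimate for compound 4 is 8000 nM, with an expected range of 2500 nM to 20000 nM.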

Compound 4, half-maximal inhibitory concentration: 320 nM
For compound 4 the middle estimate is 25-fold (1.40 log units) above the measured one, outside the stated range (below it).
By their numbers in this assay, from the lowest: compounds 4 and 2 (each within the scatter of the next); then compound 1. At a limit, above all of these: compound 3.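

In this assay, thiophen-3-yl in place of furan-3-yl gives an at least 62-fold lower number from compound 3 to compound 4 (1.79 log units; beyond the scatter), so this change on this aromatic carbon does not have one size across the two cores: the same change on two cores in this assay, a 2.9-fold lower number (0.46 log units; beyond the scatter) from compound 1 to compound 2 and an at least 62-fold lower number (1.79 log units; beyond the scatter) from compound 3 to compound 4, at least 21-fold (1.33 log units) apart, beyond the scatter of two such steps

With thiophen-3-yl present, methyl in place of dimethylamino gives a 1.7-fold lower number from compound 2 to compound 4 (0.22 log units; within the scatter), so the outcome of that change depends on the group carried on the five-membered aromatic ring: the same change on two cores in this assay, an at least 12-fold higher number (1.11 log units; beyond the scatter) from compound 1 to compound 3 and a 1.7-fold lower number (0.22 log units; within the scatter) from compound 2 to compound 4, at least 21-fold (1.33 log units) apart, beyond the scatter of two such steps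

The value of compound 3 is a limit of the assay and not a number, so the first of these gaps is only a lower bound: the limit of > 20000 nM in this assay, at which 1 of the 4 values shown sits.

Open, from the compounds shown here alone, is whether a primary amine or a longer alkyl chain in place of methyl would keep the value of compound 4 with thiophen-3-yl present. The compounds shown also cannot tell what underlies this dependence between the two places.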